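Compound 4 against the one measured clearance

The source may report more compounds than this note shows. Statements on the series, on what has been measured and on what is new or still open speak of the compounds shown alone.

In an ADME assay on microsomes from liver (Homo sapiens) for metabolic stability, read by LC-MS, with a stated time of 30 min, tested at 1 uM (on this read-out lower numbers stand for slow clearance and higher numbers for fast clearance), compound 1 `C[C@@H](c1c[nH]c2ncccc12)c1nnc2ccc(-c3cnn(C)c3)nn12` gives < 7.6 mL.min-1.g-1 and this is a limit of the assay, not a number. Compound 2 `Nc1cnc2nnn(Cc3ccc4ncccc4c3)c2n1` gives < 7.6 mL.min-1.g-1 and this too is a limit. Going by the values given here, compound 3 `COc1ccc(-c2ccc3nnc([C@@H](C)c4ccc5ncccc5c4)n3n2)cc1C` gives 304 mL.min-1.g-1 as the only actual number in the set. Compound 4 `C[C@@H](c1ccc2ncccc2c1)c1nnc2ccc(-c3ccc(N(C)C)nc3)nn12` carries 6-(dimethylamino)pyridin-3-yl in place of 4-methoxy-3-methylphenyl on an aromatic carbon. Among the compounds with values here, no measured step between compounds differing in one place is available, so any forecast is uncertain. Compound 3 at 304 mL.min-1.g-1 leaves ample room downward. A moderate fall in clearance is expected (a 2.3-fold lower number from compound 3 to compound 4 (0.37 log units; beyond the scatter)), though a change within the scatter remains possible. For compound 4 the estimated clearance is 130 mL.min-1.g-1 (40 mL.min-1.g-1 to 330 mL.min-1.g-1).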

Compound 4, intrinsic clearance in microsomes in the Homo sapiens assay: 232 mL.min-1.g-1
The estimate for compound 4 lay 1.8-fold (0.25 log units) below the measured number, and the stated range covers the measured number.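

In the Homo sapiens assay, 6-(dimethylamino)pyridin-3-yl in place of 4-methoxy-3-methylphenyl gives a 1.3-fold lower number from compound 3 to compound 4 (0.12 log units; within the scatter), so this exchange on the aromatic carbon leaves clearance unresolved from that of the parent. In a physicochemical assay for solubility, measured as kinetic solubility, at pH 6.5 (a higher number here means a more soluble compound, a lower number a less soluble compound), compound 3 gives 1770 nM and compound 4 gives 16200 nM. In the physicochemical assay, the same exchange gives a step beyond the scatter: the measured solubility of compound 3, 1770 nM, and of compound 4, 16200 nM, a 9.2-fold higher number (0.96 log units; beyond the scatter)

At this position the two read-outs therefore respond differently to one change. Going by these compounds alone, open is whether a morpholine or a carboxylic acid on this aromatic carbon would bring the Homo sapiens assay down towards the limit: the limit of < 7.6 mL.min-1.g-1 in the Homo sapiens assay, at which 2 of the 4 values shown sit. Only this one pair is available at this position, so no trend across groups can be drawn.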